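The source may hold more compounds than are shown below. What is called first, only, known or untested is meant among the compounds shown, and "the series" means these compounds.

Compound 1 `COc1nc(-c2ccc(C#N)cc2)ccc1[C@@H](c1ccccc1)[C@@](O)(CCN(C)C)c1cccc2ccccc12` carries a 4-cyanophenyl group on the shared core. In a toxicity assay on HeLa cells (Homo sapiens) for cytotoxicity (on this read-out higher numbers stand for lower toxicity in this test and lower numbers for higher toxicity in this test), compound 1 gives only a limit of the test, > 64 ug/mL. Compound 2 `COc1nc(-c2ccc(Cl)cc2)ccc1[C@@H](c1ccccc1)[C@@](O)(CCN(C)C)c1cccc2ccccc12` likewise gives only a limit in this assay, > 64 ug/mL. For compound 3 `COc1nc(-c2ccccc2F)ccc1[C@@H](c1ccccc1)[C@@](O)(CCN(C)C)c1cccc2ccccc12` no result is recorded in this assay, shown as "nd" (no result reported). Among the compounds with values here, the one step between measured compounds, a step that the two limits leave unreadable from compound 1 to compound 2, cannot be read in size because both values sit at the limit of > 64 ug/mL in this assay, at which 2 of the 3 values shown sit. Compound 4 `COc1nc(C2CCCCC2)ccc1[C@@H](c1ccccc1)[C@@](O)(CCN(C)C)c1cccc2ccccc12` differs from compound 1 by cyclohexyl in place of 4-cyanophenyl on an aromatic carbon. Within the data shown here, no measured step bears on a change of this kind, and both comparable values are limits. Compound 4 is therefore expected to sit near that limit too, estimated at 80 ug/mL with a range from 40 ug/mL to 160 ug/mL, an expected step that the limit leaves unreadable from compound 1 to compound 4.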

Compound 4, half-maximal cytotoxic concentration: 57.7 ug/mL
The estimate for compound 4 lay 1.4-fold (0.14 log units) above the measured number, and the stated range covers the measured number.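

At this position, on an aromatic carbon next to the ring nitrogen, cyclohexyl gives the first true number rather than a limit in this assay, so this non-aromatic ring brings the series onto the readable scale. The change gives an at least 1.1-fold lower number from compound 1 to compound 4 (0.04 log units; that floor lies within the scatter) and an at least 1.1-fold lower number from compound 2 to compound 4 (0.04 log units; that floor lies within the scatter). From the compounds shown here alone, its real size stays unknown because the two aryl compounds give only a limit: the limit of > 64 ug/mL in this assay, at which 2 of the 4 values shown sit. Going by these compounds, whether a smaller methyl group or a morpholine ring at this place would also give a number, and how far from that limit, remains open.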